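Moving the chlorine: from compound 2 to compound 3

A few compounds are considered here, and "the series" means these few. Any claim that something is new, unique, unknown or untested is made for them only; others in the source may bear on it.

Measured so far in a functional assay on Caco-2 cells (Homo sapiens) for inhibition, read by MTT assay, with a stated time of 48 h, tested at 10 uM; a lower number here means less inhibition of growth, a higher number more inhibition of growth at the concentration tested:
- compound 1 `CN1CC[C@H](c2c(O)cc(O)c3c(=O)cc(/C=C/c4ccccc4)oc23)[C@H](O)C1` gives 72%
- compound 2 `CN1CC[C@H](c2c(O)cc(O)c3c(=O)cc(/C=C/c4ccc(Cl)cc4)oc23)[C@H](O)C1` gives 70%

Compound 2 stands at 70% and so lies within the scatter of compound 1, and neither ranks above the other on these numbers. The next compound is compound 3 `CN1CC[C@H](c2c(O)cc(O)c3c(=O)cc(/C=C/c4cccc(Cl)c4)oc23)[C@H](O)C1`, which keeps the shared core and differs from compound 2 in one group (3-chlorophenyl in place of 4-chlorophenyl on a double-bonded chain carbon bound to a double-bonded chain carbon). The chlorine stays on the same ring, and that ring stays on a double-bonded chain carbon bound to a double-bonded chain carbon.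

Within the data shown here, only one measured step bears on this change (a number 2 percentage points lower from compound 1 to compound 2 (within the scatter)). That step, a chloro in place of hydrogen on an aromatic carbon, stays within the scatter. Among the measured compounds shown here, no measured pair yet compares two chlorine placements, so the evidence is indirect. Since adding the chlorine left no step beyond the scatter, moving it is expected to do the same. The estimated step is a number 1 percentage points lower from compound 2 to compound 3 (within the scatter) in this assay and is expected to remain inside the scatter. Compound 3 is estimated at 69% with an expected range from 57% to 80% in this series.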

Compound 3, percent growth inhibition at one concentration: 55%
For compound 3 the middle estimate is 14 percentage points above the measured one; the measured number lies below the stated range.
By their numbers in this assay, from the lowest: compound 3; then compounds 2 and 1 (each within the scatter of the next).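

In this assay, the placement of the chlorine on this ring counts for more than its presence: the exchange of 4-chlorophenyl for 3-chlorophenyl, which leaves the atoms the same and only joins them differently, gives a number 15 percentage points lower from compound 2 to compound 3 (beyond the scatter). Read against the unsubstituted phenyl of compound 1, the same addition of a chloro group has two outcomes, a number 2 percentage points lower from compound 1 to compound 2 (within the scatter) for the 4-chlorophenyl case and a number 17 percentage points lower from compound 1 to compound 3 (beyond the scatter) for the 3-chlorophenyl case, so the step measured for one chlorine placement does not carry over to the other in this series. Nothing measured here accounts for the difference between the two placements.

Still open, on these data alone, is whether the lower number belongs to chlorine itself or to any group held in the 3-chlorophenyl arrangement, which a methoxy group, a fluorine or an amine on the same ring would help to separate. Among these compounds, with only three compounds, all sharing the core and the double-bonded chain, the placement result rests on the single pair of compound 2 and compound 3 and cannot yet be extended to other substituents on this ring.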